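The source may report more compounds than this note shows. Statements on the series, on what has been measured and on what is new or still open speak of the compounds shown alone.

Measured so far in a functional assay on RAW264.7 cells (Mus musculus) for inhibition, read by microscopy and resazurin assay, with a stated time of 72 h; a lower number here means a stronger inhibitor, a higher number a weaker inhibitor:
Compound 1 `COC(=O)[C@@H](NC(=O)c1ccc(/C=C2\SC(=O)N(CC(=O)NOCc3ccccc3)C2=O)cc1)C(C)C` gives > 128000 nM.
Compound 2 `C=CCONC(=O)CN1C(=O)S/C(=C\c2cccc(C(=O)N[C@H](C(=O)OC)C(C)C)c2)C1=O` gives > 128000 nM.
Compound 3 `C=CCONC(=O)Cn1cc(C(=O)NCC(=O)N[C@H](C(=O)O)C(C)C)c2ccccc21` gives > 128000 nM.

Each of these three values is a limit of this assay, not a measured number. Compound 3 therefore has no exact position among the three: its value in this assay is only a limit. Since the other two values are limits as well, the three compounds cannot be ordered against one another; this is summed up in the limit of > 128000 nM in this assay, at which 3 of the 3 values shown sit.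

Compound 4 `C=CCONC(=O)Cn1cc(C(=O)NCC(=O)N[C@@H](CC(C)C)C(=O)O)c2ccccc21` is the compound not yet measured. It differs from compound 3 in one place: isobutyl in place of isopropyl on a saturated chain carbon bound to an amide-type nitrogen and a carbonyl carbon. For the measured compounds named here, no step between two measured compounds is available to show how such a change moves the read-out. In this assay compound 3 gives > 128000 nM, which is a limit. The expected step from compound 3 to compound 4 in this assay is a step that the limit leaves unreadable from compound 3 to compound 4, meaning none beyond the scatter. Compound 4 is therefore expected at 200000 nM, with a range from 60000 nM to 1000000 nM, and this assay will most likely again return only a limit for compound 4.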

Compound 4, half-maximal inhibitory concentration: > 128000 nM
Compound 4: no number, only a limit (the forecaster's own chance of this, stated with the estimate: 85%); the middle value lies beyond the limit too.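

In this assay compound 4 gives > 128000 nM, which is a limit and not a number. Compound 3 also returns only a limit, so no step from compound 3 to compound 4 can be read: the limit of > 128000 nM in this assay, at which 4 of the 4 values shown sit.

The compounds shown leave open whether isobutyl in place of isopropyl changes inhibition at all, and at what concentration any of them would reach half-maximal inhibition.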